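The source may report more compounds than this note shows. Statements on the series, on what has been measured and on what is new or still open speak of the compounds shown alone.

Working notes on the series in an assay on isolated protein for inhibition of 11-beta-hydroxysteroid dehydrogenase type 2 (Homo sapiens); on this read-out lower numbers stand for stronger inhibition and higher numbers for weaker inhibition. Compound 1 `Cn1c(-c2ccc(C(=O)NC3CC3)cc2)nnc1C1(c2ccc(Cl)cc2)CCC1` carries a cyclopropylcarbamoyl group on the shared core. In this assay compound 1 returns only a limit, > 4000 nM, and not a number. Compound 2 `Cn1c(-c2ccc(C(N)=O)cc2C(N)=O)nnc1C1(c2ccc(Cl)cc2)CCC1` also gives only a limit in this assay, > 4000 nM. Compound 3 `Cn1c(-c2ccc(-c3cccnc3)cc2Cl)nnc1C1(c2ccc(Cl)cc2)CCC1` likewise reaches only a limit in this assay, > 4000 nM. For the measured compounds named here, all values shown sit at the same boundary (the limit of > 4000 nM in this assay, at which 3 of the 3 values shown sit), so compound 1 cannot be ranked against compound 2 or compound 3, and no measured step between two compounds exists.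

Compound 4 `Cn1c(-c2ccc(C(=O)NC(C)(C)C)cc2)nnc1C1(c2ccc(Cl)cc2)CCC1` is not yet measured. It differs from compound 1 by tert-butyl in place of cyclopropyl on an amide-type nitrogen. Going by the values given here, with every value at the limit and no measured step, the data give no direction for this change. The expected step is therefore a step that the limit leaves unreadable from compound 1 to compound 4, none beyond the scatter. Compound 4 is expected to give 6000 nM in this assay, within 3000 nM to 15000 nM, most probably again reported only as a limit.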

Compound 4, half-maximal inhibitory concentration: > 4000 nM
Compound 4 was reported as a limit (the forecaster's own chance of this, stated with the estimate: 80%); the middle value does not contradict the limit.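

No step can be read from compound 1 to compound 4, since both results are limits and not numbers: the limit of > 4000 nM in this assay, at which 4 of the 4 values shown sit.

The compounds shown leave open how any of them ranks in this assay, and whether any change on the shared core gives a measurable value.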